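Amide Swap at the Carbonyl: Diethylamino for Isopropylamino

The compounds below may be only part of what the source reports. "The series", "measured", "known", "first", "only" and "open" are said of these compounds alone.

Compound 1 `CC(=O)C1=C(C)NC(=O)NC1c1ccoc1` gives 2% in an assay on membranes from HeLa cells for displacement of a labelled ligand from adenosine receptor A3 (Homo sapiens), read by scintillation counting, with a stated time of 180 min, tested at 1 uM; a higher number here means more inhibition at the concentration tested (going by the name of the read-out), a lower number less inhibition.
Compound 2 `CC1=C(C(=O)NC(C)C)C(c2ccoc2)NC(=O)N1` gives 3% in this assay.

Compound 2 stands alongside compound 1: the step of a number 1 percentage points higher from compound 1 to compound 2 (within the scatter) lies within the scatter, so neither shows meaningful displacement. Compound 3 `CCN(CC)C(=O)C1=C(C)NC(=O)NC1c1ccoc1` differs from compound 2 by diethylamino in place of isopropylamino on a carbonyl carbon. Going by the values given here, the one measured step at the same carbonyl carbon, a number 1 percentage points higher from compound 1 to compound 2 (within the scatter), was within the scatter, and that is the only guide. The expected step is therefore no change at the digits printed from compound 2 to compound 3 (within the scatter). Compound 3 is estimated at 3%, within a range from -5% to 12%.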

Compound 3, a percentage reported as inhibition, at one concentration (the size of the read-out at that concentration, not a potency): 37%
Estimate against measurement, compound 3: 34 percentage points below; the whole stated range lies below it.
By their numbers in this assay, from the lowest: compounds 1 and 2 (each within the scatter of the next); then compound 3.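

The step of a number 34 percentage points higher from compound 2 to compound 3 (beyond the scatter) shows that this carbonyl carbon is not indifferent to its substituent, as the first two compounds suggested. The step of a number 35 percentage points higher from compound 1 to compound 3 (beyond the scatter) adds that the missing amide hydrogen cannot be enough alone, since compound 1 has no such hydrogen either. No available data explain the rise.

Still open, as far as these compounds go, is whether both ethyl chains are needed, or whether dimethylamino, dipropylamino or a pyrrolidine ring on the same carbonyl carbon would do as well.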